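The compounds below may be only part of what the source reports. "The series", "measured", "known", "first", "only" and "open" are said of these compounds alone.

Working notes on the series. For the measured compounds named here, in an ADME assay on the whole organism (strain CD-1) for pharmacokinetics, with Mus musculus as the target, at a dose of 3 mg/kg by the intravenous route (a higher number here means more compound in the circulation at the dose given, a lower number less compound in the circulation), compound 1 (`C[C@H](CCCOc1ccccc1CN(C)C(=O)c1ccc(-c2ccco2)cc1)CC(=O)O`) gives 77700 ng.h/mL, the higher of the two numbers so far, and compound 2 (`CN(Cc1ccccc1OCCC[C@@H]1C[C@@H]1C(=O)O)C(=O)c1ccc(-c2ccco2)cc1`) gives 30100 ng.h/mL. The next comparison is compound 3 (`C/C(=C\COc1ccccc1CN(C)C(=O)c1ccc(-c2ccco2)cc1)CCC(=O)O`), not yet measured, which differs from compound 1 as follows: 4-carboxy-2-methylbut-1-en-1-yl in place of 3-(carboxymethyl)butyl on a saturated chain carbon bound to an oxygen on an aromatic ring. In words, 4-carboxy-2-methylbut-1-en-1-yl stands in place of 3-(carboxymethyl)butyl on a saturated chain carbon bound to an oxygen on an aromatic ring.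

Going by the values given here, only one measured step bears on this, and it also alters the carboxy-bearing chain: a 2.6-fold lower number from compound 1 to compound 2 (0.41 log units; beyond the scatter). Among the compounds with values here, that step is modest and beyond the scatter, but it is a different change, and no measured compound carries a double bond in this chain. It therefore guides size and direction only loosely. Within the data shown here, a small drop in this assay is expected, no larger than that step and possibly not clear of the scatter. The expected change is a 1.7-fold lower number from compound 1 to compound 3 (0.24 log units; within the scatter). For compound 3 the estimated value is 45000 ng.h/mL, with an expected range of 18000 ng.h/mL to 100000 ng.h/mL.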

Compound 3, area under the concentration-time curve: 3300 ng.h/mL
The estimate for compound 3 lay 14-fold (1.13 log units) above the measured number; measured number outside the range, below it.
By their numbers in this assay, from the lowest: compound 3; then compound 2; then compound 1.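

In this assay, the chain on the saturated chain carbon bound to an oxygen on an aromatic ring proves far more sensitive than the earlier pair could show: 4-carboxy-2-methylbut-1-en-1-yl in place of 3-(carboxymethyl)butyl gives a 24-fold lower number from compound 1 to compound 3 (1.37 log units; beyond the scatter), a large step, even though the heavy-atom count and the hydrogen-bond donor and acceptor counts stay the same, while a double bond outside aromatic rings is gained and the defined stereocentre is lost. The same group in place of 2-(2-carboxycyclopropyl)ethyl gives a 9.1-fold lower number from compound 2 to compound 3 (0.96 log units; beyond the scatter), which places compound 3 lowest of the three, with its steps to both others beyond the scatter, and shows a drop well beyond the earlier 2.6-fold lower number from compound 1 to compound 2 (0.41 log units; beyond the scatter). No measurement available here accounts for this drop.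

The double bond and the loss of the stereocentre arrive together in compound 3, so the compounds shown leave open which of them carries the step. On these data alone, how a saturated 5-carboxy-3-methylpentyl group, or a tetrazole in place of the carboxylic acid, would read in this assay also stays open.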